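Compound 4: a tertiary alcohol chain in a series at the limit

The source may report more compounds than this note shows. Statements on the series, on what has been measured and on what is new or still open speak of the compounds shown alone.

In a functional assay on NCI-H460 cells (Homo sapiens) for cytotoxicity, read by MTT assay (on this read-out higher numbers stand for weaker inhibition and lower numbers for stronger inhibition), compound 3 `Cc1c(O)cc(CCCC(C)C)oc1=O` gives only a limit (> 200000 nM). Compound 2 `CC(=O)C(C)CCCCc1cc(O)c(C)c(=O)o1` also gives only a limit (> 200000 nM). Compound 1 `COc1cc(CCCCC(C)(C)O)oc(=O)c1C`, which carries the same 2-hydroxy-2-methylpropyl, gives a limit as well (> 200000 nM). For the measured compounds named here, the one measured step is a step that the two limits leave unreadable from compound 2 to compound 3 and has no size to carry forward, so the series offers only the limit of > 200000 nM in this assay, at which 3 of the 3 values shown sit, as a guide. Compound 4 `Cc1c(O)cc(CCCCC(C)(C)O)oc1=O` has 2-hydroxy-2-methylpropyl in place of isopropyl on a saturated chain carbon, three bonds along the chain from an aromatic carbon. The expected step is a number no higher from compound 3 to compound 4 (the limit leaves the size open) and none beyond the scatter is expected in either direction. Compound 4 is estimated at 200000 nM with an expected range from 100000 nM to 400000 nM and will probably be reported as a limit again.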

Compound 4, half-maximal inhibitory concentration: > 200000 nM
Compound 4 ended at the assay's limit; the forecaster's own chance of this, stated with the estimate: 85%; the middle value lies on the limit itself.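

Compound 4 stays at a limit, so its steps from compound 1, compound 2 and compound 3 cannot be read: the limit of > 200000 nM in this assay, at which 4 of the 4 values shown sit. Whether any change among these compounds shifts the read-out in this assay remains open.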